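This account rests on a few compounds, and the source may have more. Where it says the series, first, only, none or still open, it means among the compounds named here.

Compound 1 `CC1(c2ccccc2)CC(=O)N(CC(=O)N2CCOCC2)C1=O` gives 300 mg/kg in a functional assay on the whole organism (strain CD-1) with Mus musculus as the target, in the maximal electroshock model, with a stated time of 2 h; a lower number here means that less compound is needed, a higher number that more compound is needed for the effect.
Compound 2 `CC1(c2ccccc2)CC(=O)N(CC(=O)N2CCN(c3ccc(Cl)cc3)CC2)C1=O` gives "not active" (no number reported) in this assay.
Compound 3 `CC1(c2ccccc2)CC(=O)N(CC(=O)N2CCN(c3cccc(Cl)c3)CC2)C1=O` gives 300 mg/kg in this assay.

All three compounds share the same core and differ only in the ring attached through the amide at the end of the side chain. On the numbers, compound 3 stands level with compound 1 at the digits reported, and that agreement lies within the usual scatter, so the two cannot be told apart. Compound 2 gave no number at all in this assay, only the statement that it was not active, so it offers no value to compare against.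

The next compound, compound 4 `CC1(c2ccccc2)CC(=O)N(CC(=O)N2CCN(c3ncccn3)CC2)C1=O`, keeps everything of compound 3 except one group: pyrimidin-2-yl in place of 3-chlorophenyl on an amine nitrogen in a ring. The group that leaves is 3-chlorophenyl; the group that enters is pyrimidin-2-yl, a six-membered aromatic ring with two hetero atoms and two hydrogen-bond acceptors.

Within the data shown here, no step between measured compounds is available to lean on, so the expectation rests on the flat picture from compound 1 and compound 3. A step from compound 3 to compound 4 of no more than the scatter is expected, in no particular direction. Compound 4 is therefore expected to give about 300 mg/kg, within a range from 100 mg/kg to 600 mg/kg. That estimate means an expected step of no change at the digits printed from compound 3 to compound 4 (within the scatter).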

Compound 4, minimum effective dose: "not active" (no number reported)
Nothing numeric was reported for compound 4; the estimate stays without a comparison.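

In this assay, among these compounds, compound 4 gives "not active" (no number reported) and compound 3 gives 300 mg/kg so no step between the two can be read. No measured evidence bears on this result. The compounds shown leave open how far compound 4 lies from compound 3, and what replacing 3-chlorophenyl with pyrimidin-2-yl does in this assay.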